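The source may report more compounds than this note shows. Statements on the series, on what has been measured and on what is new or still open speak of the compounds shown alone.

Compound 2 `COc1ccc2sc(NC(=O)c3ccc(C)cc3)nc2c1` bears a methoxy group on the shared core and a methyl group on a six-membered aromatic ring of carbon only attached through the amide. In a functional assay on MDA-MB-231 cells (Homo sapiens) for antiproliferative activity, read by sulforhodamine B assay (on this read-out lower numbers stand for stronger inhibition of growth and higher numbers for weaker inhibition of growth), compound 2 gives only a limit, > 10 ug/mL, so no number fixes its activity. That limit is the limit of > 10 ug/mL in this assay, at which 1 of the 3 values shown sits, and compound 2 therefore stands at the weak end of what has been measured. For comparison, compound 1 `O=C(Nc1cccc([N+](=O)[O-])c1)Nc1nc2ccc(F)cc2s1` gives 0.89 ug/mL in this assay, and compound 3 `Cc1cc(C)c2sc(NC(=O)c3ccc(C(F)(F)F)cc3)nc2c1` gives 0.45 ug/mL.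

Compound 4 `COc1ccc2sc(NC(=O)c3ccc([N+](=O)[O-])cc3)nc2c1` differs from compound 2 in one place: nitro in place of methyl on an aromatic carbon. Within the data shown here, no measured pair in this set differs in exactly this way, so the size of the step is not known from the data. Compound 1 carries a nitro group and gives 0.89 ug/mL, and compound 3 carries a trifluoromethyl group on its six-membered ring and gives 0.45 ug/mL, but both also differ from compound 2 in the core, so they offer only a loose hint toward a lower number.

Compound 4 is expected to give about 3 ug/mL, with a range from 0.6 ug/mL to 15 ug/mL. The expected step of an at least 3.3-fold lower number from compound 2 to compound 4 (0.52 log units; beyond the scatter) is toward stronger inhibition, though it may remain modest.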

Compound 4, concentration for 50% growth inhibition: > 10 ug/mL
Compound 4: only a limit was reported; the forecaster's own chance of this, stated with the estimate: 35%; middle value at least 3.3-fold (0.52 log units) from the limit.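

Among these compounds, compound 2 and compound 4 each give only a limit in this assay, so no step from one to the other can be read, and both stand at the same limit: the limit of > 10 ug/mL in this assay, at which 2 of the 4 values shown sit. The compounds shown leave open whether nitro in place of methyl on an aromatic carbon changes growth inhibition at all, and in which direction.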